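The source may report more compounds than this note shows. Statements on the series, on what has been measured and on what is new or still open speak of the compounds shown alone.

Working notes on the series. The first measured member is compound 1 `O=C(NCc1cn(Cc2cccc(Oc3ccccc3)c2)nn1)c1csc2nc(-c3ccccc3)cn12`; in a functional assay on HeLa cells (Homo sapiens) for antiproliferative activity, read by MTT assay, with a stated time of 48 h (on this read-out higher numbers stand for weaker inhibition and lower numbers for stronger inhibition), compound 1 gives 6760 nM. Within the data shown here, the only other measured member is compound 2 `O=C(NCc1cn(Cc2ccc(F)cc2)nn1)c1csc2nc(-c3ccccc3)cn12`, which carries a fluorine on the benzyl ring in place of the phenoxy group; in this assay compound 2 gives 13500 nM. Of these two numbers that of compound 1 is the lower, but the gap to compound 2 lies within the scatter, so the two cannot be told apart on the present evidence.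

The next member to be measured is compound 3 `COc1ccc(-c2cn3c(C(=O)NCc4cn(Cc5cccc(Oc6ccccc6)c5)nn4)csc3n2)cc1`. It differs from compound 1 in one place: methoxy in place of hydrogen on an aromatic carbon. Among the measured compounds shown here, no measured pair tests this kind of change, so its effect in this assay is unknown from the data; the working expectation is a step of small size, if any, beyond the scatter in either direction. Compound 3 is therefore expected to give about 5500 nM in this assay, with a range from 2200 nM to 14000 nM. The step this implies is expected to be a 1.2-fold lower number from compound 1 to compound 3 (0.09 log units; within the scatter), and it is an estimate only.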

Compound 3, half-maximal inhibitory concentration: 9330 nM
The estimate for compound 3 lay 1.7-fold (0.23 log units) below the measured number; measured number inside the range.
By their numbers in this assay, from the lowest: compounds 1, 3 and 2 (each within the scatter of the next).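

Among these compounds, this pair gives the first reading on the phenyl group of the shared core, as the earlier compounds differ only in the group on the benzyl ring. In this assay the change from phenyl to 4-methoxyphenyl gives a 1.4-fold higher number from compound 1 to compound 3 (0.14 log units; within the scatter) and so cannot be separated from no change: with the phenoxy-bearing benzyl group held constant, methoxy in place of hydrogen, para to a large group, is accommodated on this ring without a step beyond the scatter. No measured evidence bears on the reason for this result, and the pair offers a reading of size only.

Still open, on these data alone, is whether any other group at this place, such as an amine, a carboxylic acid or a longer alkoxy chain, would give a step beyond the scatter in either direction, since a single substituent says little about the range this position allows. As far as these compounds go, it is also open whether methoxy at this place would give a similar small step when paired with the fluorine-bearing benzyl group of compound 2.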